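Swapping the propanoyloxy group in a squalene synthase inhibitor

This account rests on a few compounds, and the source may have more. Where it says the series, first, only, none or still open, it means among the compounds named here.

Of the compounds shown here, three sharing a core have been measured in an assay for inhibition of squalene synthase (Rattus norvegicus), using microsomes; a lower number here means a stronger inhibitor, a higher number a weaker inhibitor. Compound 1 `CCC(=O)Nc1ccc(OCCCNC(C)C)c(Cc2ccccc2)c1` gives 0.6 nM. Compound 2 `C=CCc1cc(OC(=O)CC)ccc1OCCCNC(C)C` gives 0.05 nM, the lowest of the three numbers: compound 1 stands above it by a margin beyond the scatter, and compound 3 `C=CCc1cc(NC(=O)CC)ccc1OCCCN(C)C(C)C`, which gives 5 nM, stands further above it still. Among the compounds with values here, no pair among the three differs in only one place, so none of these gaps is assigned to a single change.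

Compound 4 `C=CCc1cc(CO/N=C/C)ccc1OCCCNC(C)C` has not yet been measured in this assay. It differs from compound 2 by a group of 5 heavy atoms (3 carbon, 1 nitrogen, 1 oxygen; no ring) in place of a group of 5 heavy atoms (3 carbon, 2 oxygen; no ring), on an aromatic carbon. The propanoyloxy group leaves and a group without a common name enters, keeping the same count of heavy atoms and acceptors while one oxygen becomes a nitrogen.

The step from compound 2 to compound 4 is expected to go toward a higher number, beyond the scatter, since the lowest value in this set belongs to compound 2 0.05 nM and every other member sits well above it, with the size given by a 10-fold higher number from compound 2 to compound 4 (1.00 log units; beyond the scatter). Compound 4 is estimated at 0.5 nM, within a range from 0.1 nM to 3 nM.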

Compound 4, half-maximal inhibitory concentration: 0.2 nM
Compound 4: the middle estimate sits 2.5-fold (0.40 log units) above what was measured, and the stated range covers the measured number.
By their numbers in this assay, from the lowest: compound 2; then compound 4; then compound 1; then compound 3.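

In this assay, within the data shown here, the change at this aromatic carbon gives the only step in the set that can be read in one place: a 4.0-fold higher number from compound 2 to compound 4 (0.60 log units; beyond the scatter). The step is modest but beyond the scatter, so this position does respond to replacing the propanoyloxy group with a group of equal heavy-atom and acceptor counts in which one oxygen becomes a nitrogen, yet the propanoyloxy group itself is not required for a low number, as compound 4 gives 0.2 nM. Nothing available here accounts for the rise in the number.

The compounds shown leave open how this position would respond to an amine, a carboxylic acid or a longer chain such as butanoyloxy. They also leave open whether this step would keep its size on the core of compound 1 or compound 3.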